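This account rests on a few compounds, and the source may have more. Where it says the series, first, only, none or still open, it means among the compounds named here.

Measured compounds:
- compound 1, `CN1C(=O)N(C)C2C1NC(=S)N2/N=C/C=C/c1ccccc1`: 46000 nM
- compound 2, `CN1C(=O)N(C)C2C1NC(=S)N2/N=C/C=C/c1ccccc1[N+](=O)[O-]`: 32400 nM

Both numbers come from a functional assay on RD cells (Homo sapiens) for inhibition, read by MTT assay, with a stated time of 72 h; on this read-out higher numbers stand for weaker inhibition and lower numbers for stronger inhibition. Compound 1 has the highest number of the two, and its nearest neighbour is compound 2, separated by a 1.4-fold lower number from compound 1 to compound 2 (0.15 log units; within the scatter), a step that stays within the scatter. Compound 3, `COc1ccc(/C=C/C=N/N2C(=S)NC3C2N(C)C(=O)N3C)cc1`, is not yet measured in this assay. It differs from compound 1 by methoxy in place of hydrogen on an aromatic carbon. For the measured compounds named here, the only measured step bearing on this change is the one from compound 1 to compound 2, where a nitro group in place of hydrogen on the aromatic carbon moved the number by a 1.4-fold lower number from compound 1 to compound 2 (0.15 log units; within the scatter), within the scatter. Going by the values given here, no step shows methoxy in place of hydrogen at this place, so the expectation rests on that single substitution step alone. For compound 3 the expected step is a 1.2-fold lower number from compound 1 to compound 3 (0.06 log units; within the scatter), that is, no change beyond the scatter. Compound 3 is therefore estimated at 40000 nM in this assay, with a range from 15000 nM to 120000 nM.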

Compound 3, half-maximal inhibitory concentration: > 100000 nM
Compound 3: only a limit was reported; the forecaster's own chance of this, stated with the estimate: 15%; middle value at least 2.5-fold (0.39 log units) away from the limit.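

In this assay, the place para to a large group on the aromatic ring responds to substitution: phenyl to 4-methoxyphenyl gives an at least 2.1-fold higher number from compound 1 to compound 3 (0.33 log units; beyond the scatter). For the compounds shown here, the only earlier step, a 1.4-fold lower number from compound 1 to compound 2 (0.15 log units; within the scatter), showed no change beyond the scatter, so this is the first ring substitution to weaken inhibition measurably. Compound 3 carries a limit and not a number, so the full size of this step cannot be read: the limit of > 100000 nM in this assay, at which 1 of the 3 values shown sits.

The compounds shown leave open whether the loss is specific to methoxy or whether fluorine, a hydroxyl or an amine at this place would give the same result. On these data alone, it is also open whether a longer chain such as ethoxy would change the number further, and how nitro would behave at this same place.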